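Mirror image of a selenium-containing inducible NOS inhibitor

A few compounds are considered here, and "the series" means these few. Any claim that something is new, unique, unknown or untested is made for them only; others in the source may bear on it.

In an assay on isolated protein for inhibition of Nitric oxide synthase, inducible (Homo sapiens) (on this read-out higher numbers stand for weaker inhibition and lower numbers for stronger inhibition), compound 1 `CC[C@H]1N=C(N)[Se][C@@H]1C` gives 9.4 nM, the second highest of three numbers. Compound 3 `CC[C@H]1SC(N)=N[C@@H]1C` gives 6.6 nM, which lies within the scatter of compound 1, while compound 2 `CC[C@@H]1N=C(N)[Se][C@@H]1C` gives 80 nM, with an 8.5-fold higher number from compound 1 to compound 2 (0.93 log units; beyond the scatter) separating them; that step is the only one bearing on configuration, and it rests on (the fact that compounds 1 and 2 differ only in the configuration as drawn). Compound 4 `CC[C@@H]1N=C(N)[Se][C@H]1C` has not been measured; it differs from compound 1 in that (the two compounds have the same atoms and bonds and differ only in configuration as drawn: 2 of 2 stereo elements differ (all stereocentres are inverted: mirror images); a stereocentre at a saturated ring carbon is drawn R in compound 1 and S in compound 4; a stereocentre at a saturated ring carbon is drawn R in compound 1 and S in compound 4). Since inverting one centre in compound 1 already gave an 8.5-fold higher number from compound 1 to compound 2 (0.93 log units; beyond the scatter), inverting both centres is expected to weaken binding as well, as a 16-fold higher number from compound 1 to compound 4 (1.20 log units; beyond the scatter), though the unknown contribution of the second centre leaves a wide band. Compound 4 is therefore estimated at 150 nM in this assay, with a range of 15 nM to 1500 nM.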

Compound 4, half-maximal inhibitory concentration: 21 nM
Compound 4: the middle estimate sits 7.1-fold (0.85 log units) above what was measured; the measured number falls inside the stated range.
By their numbers in this assay, from the lowest: compounds 3 and 1 (each within the scatter of the next); then compound 4; then compound 2.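

The two stereocentres do not add up in this assay: the mirror image loses only part of what the single inversion lost, with a 2.2-fold higher number from compound 1 to compound 4 (0.35 log units; beyond the scatter). Inverting the second centre of compound 2 moves the number back towards compound 1, with a 3.8-fold lower number from compound 2 to compound 4 (0.58 log units; beyond the scatter), so a further inversion need not weaken binding further. Both steps are changes of configuration alone: the fact that compounds 2 and 4 differ only in the configuration as drawn

On these data alone, whether the sulfur-containing compound 3 responds to inversion in the same way stays open. So does how a longer chain or a carboxylic acid on the shared core would behave in each configuration.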